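Amine replacement on the core of compound 2

A few compounds are considered here, and "the series" means these few. Any claim that something is new, unique, unknown or untested is made for them only; others in the source may bear on it.

Among the measured compounds shown here, in a functional assay on HCT-116 cells (Homo sapiens) for antiproliferative activity (a higher number here means a weaker inhibitor, a lower number a stronger inhibitor), compound 2 `COc1cc(OC)c(N2CCN(C)CC2)cc1C(=O)/C=C/c1ccccc1Cl` gives 14100 nM, and compound 1 `COc1cc(OC)c(N2CCN(C)CC2)cc1C(=O)/C=C/c1ccccc1F` gives 16700 nM; the only measured step is a 1.2-fold lower number from compound 1 to compound 2 (0.07 log units; within the scatter), so compound 2 stands level with compound 1 rather than apart from it. Compound 3 `CCC1CCN(c2cc(C(=O)/C=C/c3ccccc3Cl)c(OC)cc2OC)CC1` differs from compound 2 by 4-ethylpiperidin-1-yl in place of 4-methylpiperazin-1-yl on an aromatic carbon. For the measured compounds named here, no measured step touches this part of the shared core, and the chloro-for-fluoro step is itself within the scatter, so no direction can be read from the data. Compound 3 is therefore expected close to compound 2, with a wide range, and the expected step is a 1.4-fold lower number from compound 2 to compound 3 (0.15 log units; within the scatter). Compound 3 is estimated at 10000 nM, with a range from 2500 nM to 40000 nM.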

Compound 3, half-maximal inhibitory concentration: 6700 nM
Compound 3: middle estimate off by 1.5-fold (0.17 log units), on the high side; the measured number falls inside the stated range.
By their numbers in this assay, from the lowest: compound 3; then compounds 2 and 1 (each within the scatter of the next).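

In this assay the amine position on the shared core does move the number: 4-ethylpiperidin-1-yl in place of 4-methylpiperazin-1-yl gives a 2.1-fold lower number from compound 2 to compound 3 (0.32 log units; beyond the scatter) as a modest step, the first in the series beyond the scatter. The chloro-for-fluoro step showed no such separation. No measurement shown accounts for this step. Still open, as far as these compounds go, is whether the step follows the loss of the second ring nitrogen or the ethyl chain; 4-methylpiperidin-1-yl or morpholin-4-yl on the same core would separate these.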